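The source may hold more compounds than are shown below. What is called first, only, known or untested is meant among the compounds shown, and "the series" means these compounds.

In an ADME assay on a cell-free system (plasma, Homo sapiens) for metabolic stability, read by LC-MS, with a stated time of 60 min (on this read-out higher numbers stand for a longer-lived compound and lower numbers for a shorter-lived compound), compound 1 `O=C(NO)c1ccc(CN(C2CC2)S(=O)(=O)c2cc(F)c(F)c(F)c2F)cc1` gives 0.683 h and compound 2 `CC(C)N(Cc1ccc(C(=O)NO)cc1)S(=O)(=O)c1c(F)c(F)c(F)c(F)c1F` gives 0.367 h. These two values lie within the scatter of each other, so neither compound stands apart on this read-out. Compound 3 `CC(C)N(Cc1ccc(C(=O)NO)cc1)S(=O)(=O)c1cc(F)c(F)c(F)c1F` has not yet been measured. It differs from compound 2 in a single place, with hydrogen in place of fluoro on an aromatic carbon. Going by the values given here, no pair of measured compounds shows this change on its own, so the data give no direct measure of it. With compound 2 at 0.367 h as the only close reference, no shift beyond the scatter is expected in either direction. The estimated change, a 1.2-fold higher number from compound 2 to compound 3 (0.09 log units; within the scatter), is expected to stay within the scatter. Compound 3 is expected to give 0.45 h, with an estimated range from 0.2 h to 1 h.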

Compound 3, half-life: 1.92 h
Beside the measured number, compound 3's estimate is 4.3-fold (0.63 log units) below it; measured number above the stated range.
By their numbers in this assay, from the lowest: compounds 2 and 1 (each within the scatter of the next); then compound 3.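

In this assay, going by these compounds alone, the earlier compounds gave no direct reading of this position, but hydrogen in place of fluoro on this aromatic carbon, ortho to a large group, now brings a 5.2-fold higher number from compound 2 to compound 3 (0.72 log units; beyond the scatter), a step beyond the scatter. With hydrogen at this carbon, the sulfonamide nitrogen also proves open to change: isopropyl in place of cyclopropyl brings a 2.8-fold higher number from compound 1 to compound 3 (0.45 log units; beyond the scatter), again beyond the scatter. No measurement shown here accounts for either step.

Going by these compounds, whether the fluoro-to-hydrogen step would hold with cyclopropyl on the sulfonamide nitrogen remains open, as does where chloro or methoxy on this aromatic carbon would fall relative to compound 2 and compound 3. On these data alone, it is also open whether hydrogen in place of any of the other fluoro groups would give a similar step.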